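This account rests on a few compounds, and the source may have more. Where it says the series, first, only, none or still open, it means among the compounds named here.

Compound 1 `O=C(CSc1nc(Nc2ccccc2)c2ccccc2n1)Nc1ccccc1Br`: 19800 nM in a functional assay on PC-3 cells (Homo sapiens) for inhibition, read by MTT assay, with a stated time of 72 h; a higher number here means a weaker inhibitor, a lower number a stronger inhibitor
Compound 2 `COc1cccc(NC(=O)CSc2nc(Nc3ccccc3)c3ccccc3n2)c1`: 11600 nM

Within the data shown here, only two compounds have been measured, and compound 1 has the highest number of the pair. The gap to compound 2 is a 1.7-fold lower number from compound 1 to compound 2 (0.23 log units; within the scatter), so the two compounds cannot be told apart on these numbers.

Compound 3 `O=C(CSc1nc(Nc2ccccc2)c2ccccc2n1)Nc1ccc(Br)cc1` has not been measured. It differs from compound 1 in one place: 4-bromophenyl in place of 2-bromophenyl on an amide-type nitrogen. Among the measured compounds shown here, no measured step bears directly on this change; the only measured step, a swap on the same amide-type nitrogen, was a 1.7-fold lower number from compound 1 to compound 2 (0.23 log units; within the scatter) and lies within the scatter. With nothing to suggest otherwise, no shift beyond the scatter is expected, and the step from compound 1 to compound 3 is estimated as a 1.3-fold lower number from compound 1 to compound 3 (0.12 log units; within the scatter). For compound 3 the expected value in this assay is therefore 15000 nM, with a likely range from 5000 nM to 45000 nM.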

Compound 3, half-maximal inhibitory concentration: 8450 nM
Compound 3: middle estimate off by 1.8-fold (0.25 log units), on the high side; the measured number falls inside the stated range.
By their numbers in this assay, from the lowest: compounds 3, 2 and 1 (each within the scatter of the next, the first and the last beyond it).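

The two bromophenyl compounds contain the same atoms, so this pair isolates where the bromine sits on the phenyl group on the amide-type nitrogen. In this assay, among these compounds, 4-bromophenyl in place of 2-bromophenyl gives a modest change (a 2.3-fold lower number from compound 1 to compound 3 (0.37 log units; beyond the scatter)), the only step here beyond the scatter, so this position responds to bromine placement alone. The swap from 3-methoxyphenyl to 4-bromophenyl stays small (a 1.4-fold lower number from compound 2 to compound 3 (0.14 log units; within the scatter)), leaving compound 2 and compound 3 indistinguishable, and nothing measured explains either result.

Still open, on these data alone, is where 3-bromophenyl would fall relative to its 2-bromophenyl and 4-bromophenyl counterparts. It is also unclear whether an amine or a carboxylic acid in place of the bromine would shift the number further.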